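This account rests on a few compounds, and the source may have more. Where it says the series, first, only, none or still open, it means among the compounds named here.

In a functional assay on HUVEC cells (Homo sapiens) for inhibition (on this read-out lower numbers stand for stronger inhibition and higher numbers for weaker inhibition), compound 1 `COc1cc(/C=C/C(=O)c2cccc(NC(=O)c3ccc(Cl)cc3)c2)ccc1O` gives 0.76 ug/mL and compound 2 `COc1cc(/C=C/C(=O)c2cccc(NC(=O)c3ccco3)c2)ccc1O` gives 0.38 ug/mL while compound 3 `COc1cc(/C=C/C(=O)c2cccc(NC(=O)c3ccc(Cl)cc3Cl)c2)ccc1O` gives 0.4 ug/mL so compound 3 stands within the scatter of both others. Compound 4 `CCCC(=O)Nc1cccc(C(=O)/C=C/c2ccc(O)c(OC)c2)c1` has propyl in place of 2,4-dichlorophenyl on a carbonyl carbon. Two measured changes at that carbon bear on this (a 2.0-fold lower number from compound 1 to compound 2 (0.30 log units; within the scatter)) and (a 1.1-fold higher number from compound 2 to compound 3 (0.02 log units; within the scatter)) and both stayed within the scatter. Among the measured compounds shown here, each of those changes swapped one ring for another, so no measured compound shows a group without a ring there, and the guide is weak. The estimated step is modest (a 1.5-fold higher number from compound 3 to compound 4 (0.18 log units; within the scatter)) and no change beyond the scatter is expected. Compound 4 is estimated at 0.6 ug/mL with an expected range from 0.2 ug/mL to 1.8 ug/mL allowing for that uncertainty.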

Compound 4, half-maximal inhibitory concentration: 1.27 ug/mL
For compound 4 the middle estimate is 2.1-fold (0.33 log units) below the measured one; the range from low to high includes it.
By their numbers in this assay, from the lowest: compounds 2, 3, 1 and 4 (each within the scatter of the next, the first and the last beyond it).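

Among the compounds shown here, compound 4 is the only compound here with no ring on this carbonyl carbon, and propyl gives a step beyond the scatter against two of the rings (a 3.2-fold higher number from compound 3 to compound 4 (0.50 log units; beyond the scatter); a 3.3-fold higher number from compound 2 to compound 4 (0.52 log units; beyond the scatter)). Against 4-chlorophenyl the same change stays within the scatter (a 1.7-fold higher number from compound 1 to compound 4 (0.22 log units; within the scatter)), so a higher number on losing the ring is not seen for every ring. No measurement shown explains this.

On these data alone, whether methyl, a longer chain such as hexyl, or a dimethylamino group would behave like propyl stays open. So does whether cyclohexyl would sit with the aromatic rings or with propyl.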